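The source may report more compounds than this note shows. Statements on the series, on what has been measured and on what is new or still open speak of the compounds shown alone.

Compound 1, `FC(F)(F)Oc1ccc(Oc2ccnc(N3CCC[C@@H](NC(=S)Nc4cccnc4)C3)c2Cl)c(Cl)c1`, gives 100000 nM in an assay on membranes from brain for binding affinity to Lysophosphatidylserine lipase ABHD12 (Mus musculus), read by fluorescence, with a stated time of 20 min (on this read-out higher numbers stand for weaker inhibition and lower numbers for stronger inhibition), the highest of the two numbers recorded; its nearest neighbour, compound 2, `FC(F)(F)c1ccnc(N2CCC(NC(=S)Nc3cccnc3)CC2)c1Cl`, gives 300 nM, a difference well beyond the scatter. Compound 3, `FC(F)(F)Oc1ccc(Oc2ccnc(N3CCCC(NC(=S)Nc4cccnc4)C3)c2Cl)c(Cl)c1`, differs from compound 1 only in this way: the two compounds have the same atoms and bonds; at least one stereo element is drawn with a configuration in one of them and without one in the other: 1 of 1 stereo elements differ; a stereocentre at a saturated ring carbon is drawn R in compound 1 and without a configuration in compound 3, so the two compounds have the same atoms and bonds. Among the measured compounds shown here, no measured pair shows the effect of such a change directly. Because compound 2, also drawn without a configuration, gives 300 nM, a large step toward stronger inhibition is expected, a 1000-fold lower number from compound 1 to compound 3 (3.00 log units; beyond the scatter). Compound 3 is therefore estimated at 100 nM, within 10 nM to 3000 nM.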

Compound 3, half-maximal inhibitory concentration: 90000 nM
Beside the measured number, compound 3's estimate is 900-fold (2.95 log units) below it; the measured number lies above the stated range.
By their numbers in this assay, from the lowest: compound 2; then compounds 3 and 1 (each within the scatter of the next).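

Removing the drawn R configuration at the saturated ring carbon leaves the read-out essentially unchanged, with a 1.1-fold lower number from compound 1 to compound 3 (0.05 log units; within the scatter). So, at this position, a defined R drawing and no drawn configuration cannot be told apart by this measurement. The two compounds share all their atoms and bonds, so the only difference to consider is one of drawing: the fact that one of compounds 1 and 3 is drawn with a defined configuration and the other without, at the place where they differ

The compounds shown leave open how a form drawn S at this carbon would read. They also leave open whether a urea in place of the thiourea would shift the number.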